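The compounds below may be only part of what the source reports. "The series", "measured", "known", "first", "only" and "open" are said of these compounds alone.

Three compounds on a shared core were tested in an ADME assay on Raji cells (Homo sapiens) for cytotoxicity, with a stated time of 72 h; a lower number here means that less compound is needed, a higher number that more compound is needed for the effect. Compound 1 `Cc1cc(NC(=O)Nc2ccccc2N)c2ccccc2n1` gives only a limit there, > 25000 nM. Compound 2 `COc1ccc(NC(=O)Nc2cc(C)nc3ccccc23)cc1F` likewise shows only a limit in this assay, > 25000 nM. Compound 3 `Cc1cc(NC(=O)Nc2cccc(N(C)C)c2)c2ccccc2n1` also reaches only a limit in this assay, > 25000 nM. Compound 1 therefore stands at the limit of > 25000 nM in this assay, at which 3 of the 3 values shown sit, with no actual number known for it. Compound 4 `Cc1cc(NC(=O)Nc2ccccc2F)c2ccccc2n1` differs from compound 1 by fluoro in place of amino on an aromatic carbon. Among the compounds with values here, no pair of measured compounds differing in one place exists here, so no measured step size is available. The step that the limit leaves unreadable from compound 1 to compound 4 is expected to stay within the scatter, in no particular direction. Compound 4 is thus estimated at 30000 nM, between 10000 nM and 100000 nM, most likely reported again only as a limit.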

Compound 4, half-maximal effective concentration: > 25000 nM
Compound 4 ended at the assay's limit; the forecaster's own chance of this, stated with the estimate: 80%; the middle value does not contradict the limit.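

Within the data shown here, compound 1 and compound 4 both give only a limit, so no step between them can be read: the limit of > 25000 nM in this assay, at which 4 of the 4 values shown sit. How fluoro in place of amino changes the effect in this assay stays open, as does any ranking of these compounds.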